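Adding a methoxy group to the second aryl ring of compound 3

The compounds below may be only part of what the source reports. "The series", "measured", "known", "first", "only" and "open" are said of these compounds alone.

Measured compounds:
- compound 1, `COc1ccc(C2CC(c3ccccc3)=NN2C2=NC(=O)/C(=C3\C(=O)Nc4ccccc43)S2)cc1`: 4510 nM
- compound 2, `COc1ccc(C2=NN(C3=NC(=O)/C(=C4\C(=O)Nc5ccccc54)S3)C(c3ccc(OC)cc3)C2)cc1`: 100000 nM
- compound 3, `O=C1N=C(N2N=C(c3ccccc3)CC2c2ccc(Cl)cc2)S/C1=C1/C(=O)Nc2ccccc21`: 540 nM

In a functional assay on cells (Melanoma cell, Homo sapiens) for cytotoxicity, read by sulforhodamine B assay, with a stated time of 48 h (a higher number here means a weaker inhibitor of growth, a lower number a stronger inhibitor of growth), compound 3 gives the lowest number of the three measured compounds; the step of an 8.4-fold lower number from compound 1 to compound 3 (0.92 log units; beyond the scatter) separates it from compound 1, and compound 2 stands far higher still. Compound 4, `COc1ccc(C2=NN(C3=NC(=O)/C(=C4\C(=O)Nc5ccccc54)S3)C(c3ccc(Cl)cc3)C2)cc1`, differs from compound 3 in one place: methoxy in place of hydrogen on an aromatic carbon. The same change is already on record between two measured compounds, because the step of a 22-fold higher number from compound 1 to compound 2 (1.35 log units; beyond the scatter) shows that, starting from compound 1, placing a methoxy group on that same ring made growth inhibition much weaker. Among the measured compounds shown here, only that one step bears on the change, and it points in one direction. A rise in this assay of similar size is therefore expected for compound 4, with the step estimated as a 22-fold higher number from compound 3 to compound 4 (1.35 log units; beyond the scatter). Compound 4 is expected to give about 12000 nM in this assay, within a range of 3000 nM to 50000 nM.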

Compound 4, concentration for total growth inhibition: 100000 nM
The estimate for compound 4 lay 8.3-fold (0.92 log units) below the measured number; the measured number lies above the stated range.
By their numbers in this assay, from the lowest: compound 3; then compound 1; then compounds 2 and 4 (each within the scatter of the next).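

The methoxy group at this place, the change from phenyl to 4-methoxyphenyl, raises the number on both cores, but the size of the rise depends on what the other aryl ring carries. With chloro on that ring, this assay shows a 190-fold higher number from compound 3 to compound 4 (2.27 log units; beyond the scatter), a clearly larger rise than the one seen earlier: the same change on two cores in this assay, a 22-fold higher number (1.35 log units; beyond the scatter) from compound 1 to compound 2 and a 190-fold higher number (2.27 log units; beyond the scatter) from compound 3 to compound 4, 8.4-fold (0.92 log units) apart, beyond the scatter of two such steps. The chloro for methoxy swap, which lowered the number when this place held hydrogen, gives no change at the digits printed from compound 2 to compound 4 (within the scatter) once the 4-methoxyphenyl group is present: the same change on two cores in this assay, an 8.4-fold lower number (0.92 log units; beyond the scatter) from compound 1 to compound 3 and no change at the digits printed (within the scatter) from compound 2 to compound 4, 8.4-fold (0.92 log units) apart, beyond the scatter of two such steps. The two changes therefore do not act independently across these four compounds.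

Still open, going by these compounds, is whether this rise is specific to methoxy or would also follow from a hydroxyl, an amine or a carboxylic acid at this place. Also open, on these data alone, is how bromo or a longer chain on the other ring would behave with or without the methoxy group.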